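Chain shortening on the amide side of the shared core

The compounds below may be only part of what the source reports. "The series", "measured", "known", "first", "only" and "open" are said of these compounds alone.

Compound 3 `O=C(CCCc1ccccc1)Nc1nc2ccccc2c(=O)s1` carries a plain phenyl-terminated chain on the amide nitrogen. In an assay on CHO cells for displacement of a labelled ligand from adenosine receptor A3 (Homo sapiens), read by scintillation counting, with a stated time of 60 min (on this read-out lower numbers stand for stronger inhibition and higher numbers for weaker inhibition), compound 3 gives only the assay limit > 1000 nM, not a number. Compound 1 `COc1cccc(CCCC(=O)Nc2nc3ccccc3c(=O)s2)c1` gives 382 nM in this assay, so the step of an at least 2.6-fold higher number from compound 1 to compound 3 (0.41 log units; beyond the scatter) is read against a limit. Compound 2 `CN(C(=O)CCCc1ccccc1)c1nc2ccccc2c(=O)s1` in this assay likewise stops at the limit > 1000 nM. The step that the two limits leave unreadable from compound 2 to compound 3 cannot be sized, since the limit of > 1000 nM in this assay, at which 2 of the 3 values shown sit, fixes both ends. Compound 4 `O=C(CCc1ccccc1)Nc1nc2ccccc2c(=O)s1` differs from compound 3 by phenyl in place of benzyl on a saturated chain carbon, two bonds along the chain from a carbonyl carbon. Going by the values given here, no measured pair changes chain length, so neither step bears directly on this change. With compound 3 already at the limit, compound 4 is expected near 2000 nM, within 600 nM to 8000 nM. The expected step is a step that the limit leaves unreadable from compound 3 to compound 4.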

Compound 4, inhibition constant: 390 nM
Estimate against measurement, compound 4: 5.1-fold (0.71 log units) above; measured number below the stated range.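

Phenyl in place of benzyl on a saturated chain carbon, two bonds along the chain from a carbonyl carbon, gives an at least 2.5-fold lower number from compound 3 to compound 4 (0.40 log units; beyond the scatter) in this assay. Going by these compounds alone, this is the first step read along the chain itself, and it shows that chain length alone can bring an unsubstituted phenyl end off the limit. Its full size stays unread, as the value of compound 3 is a limit: the limit of > 1000 nM in this assay, at which 2 of the 4 values shown sit.

Open, going by these compounds, is whether a longer chain or an amine on the chain would move the number further, and whether methoxy on the phenyl of compound 4 would lower it as well.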